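This account rests on a few compounds, and the source may have more. Where it says the series, first, only, none or still open, it means among the compounds named here.

Compound 1 `CCOC(=O)C[C@H]1[C@@H](O[Si](C)(C)C(C)(C)C)[C@H](n2cnc3c(NC(=O)Nc4ccccc4)ncnc32)O[C@@H]1COC(=O)NC` and compound 2 `CNC(=O)NC[C@H]1O[C@@H](n2cnc3c(NC(=O)Nc4ccccc4)ncnc32)[C@H](O[Si](C)(C)C(C)(C)C)[C@@H]1CC(=O)N(C)OC` share a core and were both tested in a functional assay on HOP-62 cells (Homo sapiens) for antiproliferative activity; a lower number here means a stronger inhibitor of growth, a higher number a weaker inhibitor of growth. Compound 1 gives 14.7 nM, and compound 2 gives 24.9 nM; compound 2 has the higher of these two numbers, yet its gap to compound 1 lies within the scatter. Compound 3 `CCOC(=O)C[C@H]1[C@@H](O[Si](C)(C)C(C)(C)C)[C@H](n2cnc3c(NC(=O)Nc4ccccc4)ncnc32)O[C@@H]1CNC(=O)NC` has not yet been measured. It differs from compound 2 in one place: ethoxy in place of methoxy(methyl)amino on a carbonyl carbon. Going by the values given here, no step between measured compounds is known for this change, so the expected step of a 1.4-fold lower number from compound 2 to compound 3 (0.14 log units; within the scatter) is small, likely none beyond the scatter. Compound 3 is therefore estimated at 18 nM, within a range from 8 nM to 45 nM.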

Compound 3, concentration for 50% growth inhibition: 8.96 nM
Estimate against measurement, compound 3: 2.0-fold (0.30 log units) above, and the stated range covers the measured number.
By their numbers in this assay, from the lowest: compounds 3, 1 and 2 (each within the scatter of the next, the first and the last beyond it).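

In this assay, ethoxy in place of methoxy(methyl)amino on the carbonyl carbon gives a 2.8-fold lower number from compound 2 to compound 3 (0.44 log units; beyond the scatter) and shows that this position responds to the exchange by more than the scatter. The other exchange, (methylcarbamoyl)amino in place of (methylcarbamoyl)oxy on the saturated chain carbon, gives a 1.6-fold lower number from compound 1 to compound 3 (0.22 log units; within the scatter) and stays within the scatter. No measurement shown accounts for either step. Still open, going by these compounds, is how a carboxylic acid, a primary amide or a longer alkoxy chain on that carbonyl carbon would read in this assay and whether the ethoxy step holds on other cores.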